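A Larger Swap on a Weak Inhibitor

A few compounds are considered here, and "the series" means these few. Any claim that something is new, unique, unknown or untested is made for them only; others in the source may bear on it.

In a functional assay on HT-29 cells (Homo sapiens) for inhibition, read by MTT assay, with a stated time of 48 h (a higher number here means a weaker inhibitor, a lower number a stronger inhibitor), compound 1 `COc1ccc(-n2c(SCc3ccccc3)nnc2-c2cc(OC)c(OC)c(OC)c2)cc1` gives > 60000 nM, which is a limit of the assay and not a number. Within the data shown here, compound 2 `COc1ccc(-n2c(SCc3ccc(F)cc3)nnc2-c2cc(OC)c(OC)c(OC)c2)cc1` gives 50700 nM, the only true number so far. Among the measured compounds shown here, the one measured step, an at least 1.1-fold lower number from compound 1 to compound 2 (0.07 log units; that floor lies within the scatter), is only a floor, set by the limit of > 60000 nM in this assay, at which 1 of the 2 values shown sits, and it exchanges a single hydrogen for fluoro. Compound 3 `COc1ccc(-n2c(SCC(=O)c3ccc(OC)c(O)c3)nnc2-c2cc(OC)c(OC)c(OC)c2)cc1` carries a much larger change: (3-hydroxy-4-methoxyphenyl)carbonyl in place of 4-fluorophenyl on a saturated chain carbon bound to a sulfur. The fluoro step therefore offers little guidance on size. Compound 2 at 50700 nM is already a weak inhibitor, so a move towards a lower number is the likelier direction, though this remains uncertain. The expected change is a 17-fold lower number from compound 2 to compound 3 (1.23 log units; beyond the scatter). For compound 3 the estimated value is 3000 nM, with an expected range of 50 nM to 60000 nM.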

Compound 3, half-maximal inhibitory concentration: > 60000 nM
Compound 3: only a limit was reported; the forecaster's own chance of this, stated with the estimate: 15%; middle value at least 20-fold (1.30 log units) away from the limit.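

In this assay compound 3 gives > 60000 nM, a limit of the assay and not a number. Even this much larger group on a saturated chain carbon bound to a sulfur, with its carbonyl, hydroxy and methoxy, gives no stronger inhibitor than the 4-fluorophenyl it replaces, although the step is only a floor: an at least 1.1-fold higher number from compound 2 to compound 3 (0.07 log units; that floor lies within the scatter). The step between compound 1 and compound 3 cannot be read, and the limit now marks most of the compounds shown: the limit of > 60000 nM in this assay, at which 2 of the 3 values shown sit.

As far as these compounds go, the true values of compound 1 and compound 3 stay unknown, so their order remains open. Also open, from the compounds shown here alone, is whether an amine, a carboxylic acid or a longer chain on the saturated chain carbon bound to a sulfur would bring the number well down.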